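Shortening and Lengthening the Amine on a Biaryl Benzylamine

The source may report more compounds than this note shows. Statements on the series, on what has been measured and on what is new or still open speak of the compounds shown alone.

Compound 1, `CCCN(CCC)Cc1ccc(Cl)c(-c2ccccc2OC)c1`, in an assay on isolated protein for binding affinity to 5-hydroxytryptamine receptor 6 (Homo sapiens) (on this read-out higher numbers stand for weaker inhibition and lower numbers for stronger inhibition), gives > 10000 nM, which is a limit of the assay and not a number.
Compound 2, `CCNCc1ccc(Cl)c(-c2ccccc2OC)c1`, gives 1400 nM.
Compound 3, `COc1ccccc1-c1cc(CN(C)C)ccc1Cl`, gives 440 nM.

Compound 3 holds the lowest of the two numbers shown; its nearest neighbour is compound 2, and the step between them reads a 3.2-fold lower number from compound 2 to compound 3 (0.50 log units; beyond the scatter). Compound 1 sits at the limit of > 10000 nM in this assay, at which 1 of the 3 values shown sits. The two steps leading away from it are both clear: an at least 7.1-fold lower number from compound 1 to compound 2 (0.85 log units; beyond the scatter) and an at least 22-fold lower number from compound 1 to compound 3 (1.35 log units; beyond the scatter).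

Compound 4, `CCCNCc1ccc(Cl)c(-c2ccccc2OC)c1`, differs from compound 3 by propylamino in place of dimethylamino on a saturated chain carbon bound to an aromatic carbon. Two of the measured steps bear on this. The step from compound 2 to compound 3 shows that a secondary amine with a short chain gives a higher number than the small tertiary amine, and the steps from compound 1 show that long propyl chains on the nitrogen push the number up very far. Propylamino combines a secondary nitrogen with a chain longer than ethyl, so a rise beyond the scatter is expected for compound 4, estimated as a 5.7-fold higher number from compound 3 to compound 4 (0.75 log units; beyond the scatter). Compound 4 is therefore expected to give about 2500 nM, with a range from 800 nM to 8000 nM.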

Compound 4, inhibition constant: 3500 nM
Beside the measured number, compound 4's estimate is 1.4-fold (0.15 log units) below it, and the stated range covers the measured number.
By their numbers in this assay, from the lowest: compound 3; then compound 2; then compound 4. At a limit, above all of these: compound 1.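

In this assay, the two secondary amines show that chain length alone moves the number, with a 2.5-fold higher number from compound 2 to compound 4 (0.40 log units; beyond the scatter), while the change from the tertiary dimethylamino to propylamino on the saturated chain carbon bound to an aromatic carbon gives an 8.0-fold higher number from compound 3 to compound 4 (0.90 log units; beyond the scatter). Among the compounds shown, the number rises with each added chain carbon on a secondary nitrogen, and the second propyl on the nitrogen raises it further, as removing it gives an at least 2.8-fold lower number from compound 1 to compound 4 (0.45 log units; beyond the scatter). That last step has no exact size, since compound 1 stands at a limit and not at a number: the limit of > 10000 nM in this assay, at which 1 of the 4 values shown sits.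

The compounds shown leave open how methylamino, the secondary amine with the shortest chain, or the plain primary amine would compare with dimethylamino, and so whether the low number of compound 3 comes with having two chains on the nitrogen or with having short ones. Diethylamino would help to separate those two readings, and a ring amine such as pyrrolidine would show whether tying the chains together into a ring changes the number.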